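The source may report more compounds than this note shows. Statements on the series, on what has been measured and on what is new or still open speak of the compounds shown alone.

Measured so far in a physicochemical assay for solubility, using the shake flask method, in simulated intestinal fluid, measured as kinetic solubility, with a stated time of 2 h, at 25 degrees C, at pH 6.5; on this read-out higher numbers stand for higher solubility and lower numbers for lower solubility:
- compound 1 `CNC(=O)c1nc(C)c2c(c1N)C(=O)N(Cc1ccccc1)C2=O` gives 41000 nM
- compound 2 `Cc1nc(C(=O)NC#N)c(N)c2c1C(=O)N(Cc1ccccc1)C2=O` gives 185000 nM

Within the data shown here, compound 2 holds the higher of these two numbers, and the only measured step is modest but beyond the scatter: a 4.5-fold higher number from compound 1 to compound 2 (0.65 log units; beyond the scatter) when cyano replaces methyl on an amide-type nitrogen.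

The next compound, compound 3 `Cc1nc(-c2nc(C(F)(F)F)no2)c(N)c2c1C(=O)N(Cc1ccccc1)C2=O`, has not yet been measured. It carries 3-(trifluoromethyl)-1,2,4-oxadiazol-5-yl in place of cyanocarbamoyl on an aromatic carbon.

Among the measured compounds shown here, that measured step bears only loosely on this change, since here the whole cyanocarbamoyl group leaves and no measured pair shows such a swap. Even so, a clear fall is expected, larger than the measured step, though this direction is a judgement and not a measured trend. The estimate is a 23-fold lower number from compound 2 to compound 3 (1.36 log units; beyond the scatter) in this assay as the expected move.

For compound 3 the estimated value is 8000 nM, with an expected range of 1500 nM to 40000 nM as its limits.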

Compound 3, solubility: < 5000 nM
Compound 3 was reported as a limit; the forecaster's own chance of this, stated with the estimate: 10%; middle value at least 1.6-fold (0.20 log units) from the limit.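

In this assay compound 3 gives < 5000 nM, which is a limit and not a number. Until now only the substituent on the amide-type nitrogen had changed, whereas here the whole carbamoyl group on the aromatic carbon next to the ring nitrogen gives way to a 3-(trifluoromethyl)-1,2,4-oxadiazol-5-yl ring, and the step is large: an at least 37-fold lower number from compound 2 to compound 3 (1.56 log units; beyond the scatter). The fall also holds against the methylcarbamoyl group, with an at least 8.2-fold lower number from compound 1 to compound 3 (0.91 log units; beyond the scatter), so this position responds to the swap whichever of the two carbamoyl groups leaves.

The compounds shown cannot separate the part played by the five-membered ring from that of the trifluoromethyl group on it, and the true value of compound 3 stays unknown. The same ring carrying a methyl group, or a carboxylic acid at this carbon, remains an open comparison.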